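Formyl to hydroxymethyl on the enal chain, two scaffolds

The source may hold more compounds than are shown below. What is called first, only, known or untested is meant among the compounds shown, and "the series" means these compounds.

Compound 1 `Cc1cn(/C=C/C=O)c(=O)[nH]c1=O` gives 25000 nM in a functional assay on HeLa cells (Homo sapiens) for inhibition; a lower number here means a stronger inhibitor, a higher number a weaker inhibitor. Compound 2 `Cc1cn(/C=C/CO)c(=O)[nH]c1=O` reaches only > 100000 nM in this assay, and this value is a limit of the assay rather than a number. The step of an at least 4.0-fold higher number from compound 1 to compound 2 (0.60 log units; beyond the scatter) follows the change (hydroxymethyl in place of formyl on a double-bonded chain carbon bound to a double-bonded chain carbon); it is known only as a lower bound because of the limit of > 100000 nM in this assay, at which 1 of the 3 values shown sits.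

Compound 3 `Cc1cn([C@H]2C[C@H](O)[C@@H](CO)O2)c(=O)n(/C=C/C=O)c1=O` gives 15000 nM in this assay, a value within the scatter of that of compound 1. The difference between the core of compound 1 and the core of compound 3 is not broken down here.

Compound 4 `Cc1cn([C@H]2C[C@H](O)[C@@H](CO)O2)c(=O)n(/C=C/CO)c1=O` is not yet measured in this assay. It differs from compound 3 by hydroxymethyl in place of formyl on a double-bonded chain carbon bound to a double-bonded chain carbon, the same change as from compound 1 to compound 2, at the same place. The step is expected to be a 5.3-fold higher number from compound 3 to compound 4 (0.73 log units; beyond the scatter), resting on the step of an at least 4.0-fold higher number from compound 1 to compound 2 (0.60 log units; beyond the scatter), which on the core of compound 1 weakened inhibition at least modestly. Compound 4 is therefore estimated at 80000 nM in this assay, with the likely range 30000 nM to 300000 nM, and a fair chance that only a limit is reported.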

Compound 4, half-maximal inhibitory concentration: > 100000 nM
Compound 4 was reported as a limit; the forecaster's own chance of this, stated with the estimate: 40%; middle value at least 1.2-fold (0.09 log units) from the limit.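

Replacing formyl with hydroxymethyl on a double-bonded chain carbon bound to a double-bonded chain carbon weakens inhibition on both cores shown, and on the second core the step is an at least 6.6-fold higher number from compound 3 to compound 4 (0.82 log units; beyond the scatter). In this assay compound 4 gives > 100000 nM, which is a limit of the assay and not a number. The change therefore carries over between these two cores in direction, but the data do not show that it carries over with the same size, since both steps are known only as lower bounds: the same change on two cores in this assay, an at least 4.0-fold higher number (0.60 log units; beyond the scatter) from compound 1 to compound 2 and an at least 6.6-fold higher number (0.82 log units; beyond the scatter) from compound 3 to compound 4; the limit leaves it open whether they differ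

The compounds shown hold only formyl and hydroxymethyl at this place; how a carboxylic acid, an amine or a longer chain there would read in this assay remains open. Also open is how much weaker the two hydroxymethyl compounds really are, as neither has a number of its own: the limit of > 100000 nM in this assay, at which 2 of the 4 values shown sit.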